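Swapping pyridin-4-yl for 2-cyanophenyl: cytotoxicity outlook

This account rests on a few compounds, and the source may have more. Where it says the series, first, only, none or still open, it means among the compounds named here.

Measured compounds:
Compound 1 `Nc1ccc(CN2N=C(c3ccc(F)cc3)C3C=CC=CC3C2=O)cc1` gives in an ADME assay on Huh-7 cells (Homo sapiens) for cytotoxicity, read by MTT assay, with a stated time of 48 h (a higher number here means that more compound is tolerated, a lower number that less compound is tolerated), a value of > 80000 nM, which is a limit of the assay rather than a number.
Compound 2 `CN(C)CCCCN(C(=O)O)c1cccc(Cn2nc(-c3ccc(F)cc3)c3ccccc3c2=O)c1` gives in this assay a value of 8510 nM.
Compound 3 `CN(C)CCCCOC(=O)Nc1ccc(Cn2nc(-c3ccncc3)c3ccccc3c2=O)cc1` gives in this assay a value of 62700 nM.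

Among the two numbers, compound 3 has the highest, with compound 2 standing a good deal lower, beyond the scatter. For compound 1 only a limit is known, (the limit of > 80000 nM in this assay, at which 1 of the 3 values shown sits), so its place relative to compound 3 cannot be fixed.

Compound 4 `CN(C)CCCCOC(=O)Nc1ccc(Cn2nc(-c3ccccc3C#N)c3ccccc3c2=O)cc1` is not yet measured. It differs from compound 3 in one place: 2-cyanophenyl in place of pyridin-4-yl on an aromatic carbon. Going by the values given here, no step between two measured compounds mirrors this change, so there is nothing measured to anchor an expectation. The step from compound 3 to compound 4 in this assay is therefore expected to be small, a 1.3-fold lower number from compound 3 to compound 4 (0.10 log units; within the scatter), with no clear direction beyond the scatter. Compound 4 is estimated at 50000 nM, within a range from 20000 nM to 100000 nM.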

Compound 4, half-maximal cytotoxic concentration: 90700 nM
For compound 4 the middle estimate is 1.8-fold (0.26 log units) below the measured one; measured number inside the range.
By their numbers in this assay, from the lowest: compound 2; then compounds 3 and 4 (each within the scatter of the next).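

In this assay, the exchange of pyridin-4-yl for 2-cyanophenyl gives a 1.4-fold higher number from compound 3 to compound 4 (0.16 log units; within the scatter), so the two compounds cannot be told apart, even though a ring of carbon only and a nitrile enter in place of a ring with a nitrogen. Going by these compounds alone, this is the first measured step at this position on the shared core, since no two earlier compounds differ in just one place. Compound 1 differs from both in more than one place and is known only as a limit of the assay: the limit of > 80000 nM in this assay, at which 1 of the 4 values shown sits.

One step says nothing about other groups at this position, such as a primary amine or a carboxylic acid on the carbon ring. Going by these compounds, whether the same exchange would stay within the scatter with a longer chain on the carbamate also remains open.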